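The compounds below may be only part of what the source reports. "The series", "measured", "known", "first", "only" and "open" are said of these compounds alone.

The series shares one core, seen in compound 1 `CCC1C(=O)N(C)c2cnc(-n3ccc4cc(C(N)=O)ccc43)nc2N1c1ccn(C)n1`, which in a functional assay on Huh-7 cells (Homo sapiens) for antiproliferative activity, read by CCK-8 assay, with a stated time of 72 h (on this read-out higher numbers stand for weaker inhibition of growth and lower numbers for stronger inhibition of growth), is reported as "not active" (no number reported), so that no number stands for it. Compound 2 `CCC1C(=O)N(C)c2cnc(-n3ccc4cc(C(=O)NC)ccc43)nc2N1c1ccn(C)n1` carries a methylcarbamoyl group in place of the carboxamide of compound 1, and in this assay compound 2 gives 13200 nM, the highest of the two numbers measured. Compound 3 `CCCNS(=O)(=O)c1ccc(Nc2ncc3c(n2)N(c2ccn(C)n2)C(CC)C(=O)N3C)cc1` has a different outer part on the same core, and in this assay compound 3 gives 8880 nM, a value that lies within the scatter of that of compound 2, so the two cannot be ordered.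

Compound 4 `CCC1C(=O)N(C)c2cnc(-n3ccc4cc(C(=O)NC(C)C)ccc43)nc2N1c1ccn(C)n1` differs from compound 2 in a single place: isopropyl in place of methyl on an amide-type nitrogen. Within the data shown here, no pair of measured compounds shows this change, so nothing in the data fixes its size or direction. Compound 2 and compound 3 sit close together, and a methyl-to-isopropyl exchange on an amide-type nitrogen is expected to move the number only modestly, if at all. The step from compound 2 to compound 4 is therefore estimated at a 1.3-fold lower number from compound 2 to compound 4 (0.12 log units; within the scatter), within or near the scatter. Compound 4 is expected to give about 10000 nM in this assay, with a likely range from 4000 nM to 30000 nM.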

Compound 4, concentration for 50% growth inhibition: 6740 nM
Estimate against measurement, compound 4: 1.5-fold (0.17 log units) above, within the range that was stated.
By their numbers in this assay, from the lowest: compounds 4, 3 and 2 (each within the scatter of the next).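

In this assay, among these compounds, isopropyl in place of methyl on the amide-type nitrogen gives a 2.0-fold lower number from compound 2 to compound 4 (0.29 log units; within the scatter), the first step that can be read at this position. The methylcarbamoyl and isopropylcarbamoyl groups therefore cannot be told apart on this read-out, and this exchange gives no sign that the size of the group on this nitrogen governs growth inhibition here. Nothing measured on these compounds speaks to the reason for this result.

Going by these compounds, it remains open whether a longer chain, a cyclopropyl ring or a chain ending in an amine on this nitrogen would move the number beyond the scatter. On these data alone, the step to compound 1 cannot be read, since compound 1 is reported only as "not active" (no number reported), so the effect of removing the alkyl group stays unknown.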